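Cytotoxicity notes on the aryl exchange toward compound 4

The compounds below may be only part of what the source reports. "The series", "measured", "known", "first", "only" and "open" are said of these compounds alone.

Of the compounds shown here, three have been read in an ADME assay on TZM-b1 cells (Homo sapiens) for cytotoxicity, read by XTT assay, with a stated time of 3 days; a lower number here means that less compound is tolerated, a higher number that more compound is tolerated. Compound 1 `Cc1nc(C(NC(=O)C(=O)Nc2ccc(F)cc2F)C2CCCCN2)sc1CO` reaches only a limit there, > 87000 nM, so its standing is known as a limit and not as a number. Compound 2 `Cc1nc(C(NC(=O)C(=O)Nc2ccc(F)cc2F)C2CCCCN2)sc1CCO` likewise gives only a limit, > 84000 nM. Compound 3 `Cc1nc(C(NC(=O)C(=O)Nc2ccc(Cl)cc2)C2CCNCC2)sc1CCO`, which differs from the others in more than one place, gives a number, 85400 nM. Among the measured compounds shown here, the single measured step, a step that the two limits leave unreadable from compound 1 to compound 2, rests on two limits, the limit of > 84000 nM in this assay, at which 1 of the 3 values shown sits, and (the limit of > 87000 nM in this assay, at which 1 of the 3 values shown sits), and cannot be sized; it concerns the hydroxymethyl in place of hydroxy on a saturated chain carbon bound to an aromatic carbon, not the aryl group on the amide-type nitrogen. Compound 4 `Cc1nc(C(NC(=O)C(=O)Nc2ccc(F)c(Cl)c2)C2CCCCN2)sc1CO` is the next to be measured; it differs from compound 1 by 3-chloro-4-fluorophenyl in place of 2,4-difluorophenyl on an amide-type nitrogen. For the measured compounds named here, no measured step bears on this exchange. The expected step is a step that the limit leaves unreadable from compound 1 to compound 4, within the scatter, and most likely again only a limit. The estimate for compound 4 in this assay is 90000 nM, between 40000 nM and 200000 nM.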

Compound 4, half-maximal cytotoxic concentration: > 77800 nM
Compound 4 was reported as a limit; the forecaster's own chance of this, stated with the estimate: 70%; the middle value lies beyond the limit too.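

In this assay compound 4 gives > 77800 nM, which is a limit. Among the compounds shown here, compound 1 also stands only as a limit, so no step from it to compound 4 can be read. The compounds shown leave open whether 3-chloro-4-fluorophenyl in place of 2,4-difluorophenyl changes the half-maximal cytotoxic concentration at all.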